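The source may hold more compounds than are shown below. What is called first, only, known or untested is meant among the compounds shown, and "the series" means these compounds.

The three compounds shown share one core. Compound 1 `O=C(NNc1ccccc1F)c1ccc(NS(=O)(=O)c2cnc(O)nc2O)cc1` was tested in a functional assay on MDA-MB-231 cells (Homo sapiens) for antiproliferative activity, read by MTT assay, with a stated time of 24 h; on this read-out lower numbers stand for stronger inhibition and higher numbers for weaker inhibition; in this assay compound 1 reaches only the limit > 20000 nM, which is not a number. Compound 3 `O=C(NNC(=O)c1ccc(NS(=O)(=O)c2cnc(O)nc2O)cc1)c1ccc(F)cc1` likewise gives in this assay only the limit > 20000 nM. Among the measured compounds shown here, compound 2 `O=C(NNc1cccc(Cl)c1)c1cccc(NS(=O)(=O)c2cnc(O)nc2O)c1` is the single compound with a number: in this assay compound 2 gives 7760 nM. The values of compound 1 and compound 3 are not numbers. Compound 4 `O=C(NNC(=O)c1cccc(NS(=O)(=O)c2cnc(O)nc2O)c1)c1ccc(F)cc1` is not yet measured; from compound 2 it differs as follows: (4-fluorophenyl)carbonyl in place of 3-chlorophenyl on an amine nitrogen. The closest measured step is a step that the two limits leave unreadable from compound 1 to compound 3, whose size cannot be read because the limit of > 20000 nM in this assay, at which 2 of the 3 values shown sit, holds both of its ends. The change is therefore expected to weaken inhibition by about a 1.9-fold higher number from compound 2 to compound 4 (0.29 log units; within the scatter), with a real chance that only a limit is reported. Compound 4 is expected to give 15000 nM, between 6000 nM and 40000 nM.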

Compound 4, half-maximal inhibitory concentration: > 20000 nM
Compound 4 was reported as a limit; the forecaster's own chance of this, stated with the estimate: 55%; middle value at least 1.3-fold (0.12 log units) from the limit.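

On an amine nitrogen, (4-fluorophenyl)carbonyl in place of 3-chlorophenyl gives in this assay an at least 2.5-fold higher number from compound 2 to compound 4 (0.41 log units; beyond the scatter). This puts a readable lower bound on a change of this kind, which the unreadable step between compound 1 and compound 3 could not do. The full size stays unknown because compound 4 is reported only as a limit: the limit of > 20000 nM in this assay, at which 3 of the 4 values shown sit.

From the compounds shown here alone, whether the carbonyl or the swap of chlorine for fluorine matters more stays open, as both change together in this step. Going by these compounds, how an acetyl group or a carboxylic acid on this nitrogen would behave also stays open.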